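4-Chlorophenyl to 4-methylphenyl: working notes on the series

A few compounds are considered here, and "the series" means these few. Any claim that something is new, unique, unknown or untested is made for them only; others in the source may bear on it.

In a functional assay on A549 cells (Homo sapiens) for inhibition (a higher number here means a weaker inhibitor, a lower number a stronger inhibitor), compound 1 `O=C(CC(CC(=O)NC1Cc2ccccc2C1)c1ccc(Cl)cc1)NCCN1CCCCC1` gives 28000 nM, compound 2 `CCN(CC)CCNC(=O)CC(CC(=O)NC1Cc2ccccc2C1)c1ccc(Cl)cc1` gives 48600 nM and compound 3 `O=C(CC(CC(=O)NC1Cc2ccccc2C1)c1ccc(Cl)cc1)NCCN1CCCC1` gives 50900 nM. All three values lie within the scatter of one another, so compound 1 stands level with the other two.

Compound 4 `Cc1ccc(C(CC(=O)NCCN2CCCCC2)CC(=O)NC2Cc3ccccc3C2)cc1` keeps the core of compound 1 and carries methyl in place of chloro on an aromatic carbon, para to a large group: methyl in place of chloro on an aromatic carbon.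

Three measured steps are available: a 1.7-fold higher number from compound 1 to compound 2 (0.24 log units; within the scatter), a 1.8-fold higher number from compound 1 to compound 3 (0.26 log units; within the scatter) and a 1.0-fold higher number from compound 2 to compound 3 (0.02 log units; within the scatter). Each lies within the scatter, but each only exchanges piperidin-1-yl, diethylamino or pyrrolidin-1-yl on the saturated chain. None touches the 4-chlorophenyl group, so the series holds no direct measure of the change to 4-methylphenyl. These steps bear on it only indirectly, as a sign of how little the numbers in this assay have moved so far, and three compounds are a thin basis for that. No step beyond the scatter is therefore expected, and no direction can be assigned with confidence.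

The expected step is a 1.3-fold higher number from compound 1 to compound 4 (0.10 log units; within the scatter). For compound 4 the estimated value is 35000 nM, with an expected range from 14000 nM to 85000 nM.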

Compound 4, half-maximal inhibitory concentration: > 100000 nM
Compound 4: a limit, no number (the forecaster's own chance of this, stated with the estimate: 10%); middle value at least 2.8-fold (0.45 log units) away from the limit.
By their numbers in this assay, from the lowest: compounds 1, 2 and 3 (each within the scatter of the next). At a limit, above all of these: compound 4.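

In this assay compound 4 sits at > 100000 nM, which is a limit of the assay and not a number. Methyl in place of chloro on an aromatic carbon, para to a large group, gives an at least 3.5-fold higher number from compound 1 to compound 4 (0.55 log units; beyond the scatter), whereas the exchanges of piperidin-1-yl, diethylamino and pyrrolidin-1-yl on the saturated chain all stayed within the scatter, so this position is the first place in the series where the number moves beyond it. The change swaps one heavy atom for one heavy atom, with no ring, hydrogen-bond donor, hydrogen-bond acceptor or net charge entering or leaving, yet it is not silent, and the full size of the step stays unread: the limit of > 100000 nM in this assay, at which 1 of the 4 values shown sits.

As far as these compounds go, with only chloro and methyl at this position, it remains open whether an unsubstituted phenyl, fluoro, bromo or methoxy would stay level with chloro or fall with methyl. From the compounds shown here alone, it is equally open whether the same exchange of chloro for methyl would carry over with diethylamino or pyrrolidin-1-yl on the chain in place of piperidin-1-yl.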